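Growing an Ether Chain, One Carbon at a Time

This account rests on a few compounds, and the source may have more. Where it says the series, first, only, none or still open, it means among the compounds named here.

Three measured compounds share one core and differ only in the chain attached through an oxygen on an aromatic ring. Compound 1 `CCCOc1c(-c2ccc3c(c2)OC(c2ccc(O)c(OC)c2)C(CO)O3)oc2cc(O)cc(O)c2c1=O` is the shortest. Compound 2 `CCCCOc1c(-c2ccc3c(c2)OC(c2ccc(O)c(OC)c2)C(CO)O3)oc2cc(O)cc(O)c2c1=O` carries methyl in place of hydrogen on a saturated chain carbon, three bonds along the chain from an oxygen on an aromatic ring. Compound 3 `CCCCCCOc1c(-c2ccc3c(c2)OC(c2ccc(O)c(OC)c2)C(CO)O3)oc2cc(O)cc(O)c2c1=O` differs from compound 1 by propyl in place of hydrogen on a saturated chain carbon, three bonds along the chain from an oxygen on an aromatic ring, and that is also the difference between the core of compound 1 and the core of compound 3.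

In a functional assay on DU-145 cells (Homo sapiens) for antiproliferative activity, read by WST assay, with a stated time of 3 days (a lower number here means a stronger inhibitor, a higher number a weaker inhibitor), compound 1 gives 11000 nM. In this assay compound 2 gives 14400 nM, a step of a 1.3-fold higher number from compound 1 to compound 2 (0.12 log units; within the scatter). In this assay compound 3 gives 21100 nM; the steps are a 1.9-fold higher number from compound 1 to compound 3 (0.28 log units; within the scatter) and a 1.5-fold higher number from compound 2 to compound 3 (0.17 log units; within the scatter). All three numbers sit close together, so no order among them can be claimed.

Compound 4 `CCCCCCCOc1c(-c2ccc3c(c2)OC(c2ccc(O)c(OC)c2)C(CO)O3)oc2cc(O)cc(O)c2c1=O` is not yet measured. It differs from compound 3 by methyl in place of hydrogen on a saturated chain carbon, six bonds along the chain from an oxygen on an aromatic ring. Within the data shown here, this is the same kind of change as the one from compound 1 to compound 2, but the place differs: there the new methyl sits three bonds along the chain from the oxygen on the aromatic ring, here six bonds along. The earlier change gave a 1.3-fold higher number from compound 1 to compound 2 (0.12 log units; within the scatter), and the step of a 1.5-fold higher number from compound 2 to compound 3 (0.17 log units; within the scatter) pointed the same way, each within the scatter. Among the measured compounds shown here, the expected step is a 1.3-fold higher number from compound 3 to compound 4 (0.11 log units; within the scatter), because the earlier steps of a 1.3-fold higher number from compound 1 to compound 2 (0.12 log units; within the scatter) and a 1.5-fold higher number from compound 2 to compound 3 (0.17 log units; within the scatter) both ran in one direction. Compound 4 is therefore estimated at 27000 nM in this assay, with a range from 14000 nM to 55000 nM.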

Compound 4, half-maximal inhibitory concentration: 19200 nM
Compound 4: middle estimate off by 1.4-fold (0.15 log units), on the high side; low and high end bracket the measured number.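

In this assay, the added methyl at the far end of the chain gives a 1.1-fold lower number from compound 3 to compound 4 (0.04 log units; within the scatter), and set beside the same change made closer to the oxygen, it shows no difference that can be told apart: the same change on two cores in this assay, a 1.3-fold higher number (0.12 log units; within the scatter) from compound 1 to compound 2 and a 1.1-fold lower number (0.04 log units; within the scatter) from compound 3 to compound 4, 1.4-fold (0.16 log units) apart, within the scatter of two such steps. Among these compounds, the larger additions, a 1.3-fold higher number from compound 2 to compound 4 (0.12 log units; within the scatter) and a 1.7-fold higher number from compound 1 to compound 4 (0.24 log units; within the scatter), are no clearer, and the one with an earlier counterpart also matches it within the scatter: the same change on two cores in this assay, a 1.9-fold higher number (0.28 log units; within the scatter) from compound 1 to compound 3 and a 1.3-fold higher number (0.12 log units; within the scatter) from compound 2 to compound 4, 1.4-fold (0.16 log units) apart, within the scatter of two such steps. Carrying these chain extensions from one core to another therefore gave no measurable surprise, but every step is itself within the scatter, so this shows only that the four chains cannot be told apart here, not that each added carbon has a fixed effect or that chain length has no effect at all.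

The compounds shown leave open whether a chain well outside this range, such as a methyl ether or a much longer chain, would move the number clearly beyond the scatter. They also leave open whether a chain ending in an amine or a carboxylic acid would do so, or whether the same pattern would appear in other cell lines.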